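Anilinopyrimidine thioether series: growth inhibition notes

This account rests on a few compounds, and the source may have more. Where it says the series, first, only, none or still open, it means among the compounds named here.

Measured so far:
compound 1 `CC(=O)c1ccc(Nc2ccnc(SCC(=O)c3ccc(Br)cc3)n2)cc1` 16%
compound 2 `CCOC(=O)c1ccc(Nc2ccnc(SCC(=O)c3ccc(C#N)cc3)n2)cc1` 20%
compound 3 `CC(=O)c1cccc(Nc2ccnc(SCC(=O)c3ccc(-c4ccccc4)cc3)n2)c1` 18%

In a functional assay on NCI-H23 cells (Homo sapiens) for inhibition, read by sulforhodamine B assay, with a stated time of 48 h, tested at 10 uM (a higher number here means more inhibition of growth at the concentration tested, a lower number less inhibition of growth), compound 3 stands second highest of the three numbers. Its nearest neighbour is compound 1, whose value in this assay is 16% and lies within the scatter; the furthest is compound 2, whose 20% also lies within the scatter. The three measured numbers therefore cannot be told apart.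

Compound 4 `COc1ccc(C(=O)CSc2nccc(Nc3cccc(C(C)=O)c3)n2)cc1` is still to be measured. It differs from compound 3 by methoxy in place of phenyl on an aromatic carbon, para to a large group. Going by the values given here, no step between measured compounds covers this change. With all measured values close together, no step beyond the scatter is expected, in either direction. Compound 4 is estimated at 17% (range 5% to 30%); the expected step of a number 1 percentage points lower from compound 3 to compound 4 (within the scatter) is small.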

Compound 4, percent growth inhibition at one concentration: 19%
Compound 4: the middle estimate sits 2 percentage points below what was measured, and the stated range covers the measured number.
By their numbers in this assay, from the lowest: compounds 1, 3, 4 and 2 (each within the scatter of the next).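

In this assay the step is a number 1 percentage points higher from compound 3 to compound 4 (within the scatter) for methoxy in place of phenyl on an aromatic carbon, para to a large group. Going by these compounds alone, this is the only step that can be read at this position, and it shows that a six-membered aromatic ring of carbon only can give way to a group of 2 heavy atoms with no change beyond the scatter. Nothing on hand offers an explanation for this result.

On these data alone, whether an amine or a carboxylic acid at this position would give a step beyond the scatter remains open. Also open, as far as these compounds go, is whether methoxy in place of phenyl would read the same on the core of compound 1.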